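The source may hold more compounds than are shown below. What is called first, only, known or untested is meant among the compounds shown, and "the series" means these compounds.

Compound 3, `CC(=O)Nc1ccc(S(=O)(=O)NNc2ccc(C(F)(F)F)cc2)cc1`, gives 181 nM in an assay on HeLa cells for inhibition of Indoleamine 2,3-dioxygenase 1 (Homo sapiens), read by spectrophotometry, with a stated time of 24 h; a lower number here means that less compound is needed, a higher number that more compound is needed for the effect. Among the two numbers available it stands lowest; its nearest neighbour is compound 2, `CC(=O)Nc1ccc(S(=O)(=O)NNc2ccc(C#N)cc2)cc1`, which in this assay gives 1390 nM, a step summarised as a 7.7-fold lower number from compound 2 to compound 3 (0.89 log units; beyond the scatter). Compound 1, `COc1ccc(NNS(=O)(=O)c2ccc(NC(C)=O)cc2)cc1`, reaches only the limit of this assay, > 10000 nM, which is a limit and not a number (the limit of > 10000 nM in this assay, at which 1 of the 3 values shown sits). From there the steps are an at least 7.1-fold lower number from compound 1 to compound 2 (0.85 log units; beyond the scatter) and an at least 55-fold lower number from compound 1 to compound 3 (1.74 log units; beyond the scatter).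

Compound 4 is `CC(=O)Nc1ccc(S(=O)(=O)NNc2ccc(Cl)cc2)cc1`. It differs from compound 3 in one place: chloro in place of trifluoromethyl on an aromatic carbon. All three measured steps concern a group exchanged on the same aromatic carbon of the shared core, and each change away from trifluoromethyl has so far given a higher number, by a modest to large margin. A chloro group has not been measured in this series, so the expectation rests on that pattern alone. For compound 4 a modest rise in this assay is expected, a 2.5-fold higher number from compound 3 to compound 4 (0.40 log units; beyond the scatter), and the estimated value is 450 nM, within 150 nM to 1500 nM.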

Compound 4, half-maximal effective concentration: 142 nM
For compound 4 the middle estimate is 3.2-fold (0.50 log units) above the measured one, and the stated range ends above it.
By their numbers in this assay, from the lowest: compounds 4 and 3 (each within the scatter of the next); then compound 2. At a limit, above all of these: compound 1.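

Chloro and trifluoromethyl on this aromatic carbon, para to a large group, cannot be told apart in this assay: there is a 1.3-fold lower number from compound 3 to compound 4 (0.11 log units; within the scatter). Chloro, with 1 heavy atom against the 4 of trifluoromethyl, therefore gives a number in the same range, and it keeps the same clear separation from the other two groups, with a 9.8-fold lower number from compound 2 to compound 4 (0.99 log units; beyond the scatter) and an at least 70-fold lower number from compound 1 to compound 4 (1.84 log units; beyond the scatter). The value of compound 1 is a limit and not a number, so that last step has no upper bound: the limit of > 10000 nM in this assay, at which 1 of the 4 values shown sits.

The compounds shown leave open whether a bromo, a methyl or an amine on this carbon would fall with chloro and trifluoromethyl or with cyano and methoxy. From the compounds shown here alone, how far compound 1 actually lies from the others also stays open.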